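The source may report more compounds than this note shows. Statements on the series, on what has been measured and on what is new or still open speak of the compounds shown alone.

Compound 1 `CC(C)(C)c1ccc(C(=O)N2CCC3(CC2)C(=O)N(CC(=O)NCCCN)CN3c2ccccc2)cc1`: 4200 nM
Compound 2 `CS(=O)(=O)N1CCN(C(=O)CN2CN(c3ccccc3)C3(CCN(C(=O)c4ccc(C5CCCCC5)cc4)CC3)C2=O)CC1`: 6300 nM

In an assay on HEK293 cells for displacement of a labelled ligand from NPC1-like intracellular cholesterol transporter 1 (Homo sapiens) (on this read-out higher numbers stand for weaker inhibition and lower numbers for stronger inhibition), compound 1 gives 4200 nM, the smaller of the two numbers shown, while compound 2 gives 6300 nM, a gap that lies within the usual scatter. Compound 3 `CC(C)(C)c1ccc(C(=O)N2CCC3(CC2)C(=O)N(CC(=O)N2CCNCC2)CN3c2ccccc2)cc1` differs from compound 1 in one place: piperazin-1-yl in place of (3-aminopropyl)amino on a carbonyl carbon. Among the compounds with values here, no measured pair shows this change, so the expected step is a 1.2-fold higher number from compound 1 to compound 3 (0.08 log units; within the scatter), nothing beyond the scatter, in either direction. The number for compound 3 is therefore estimated near that of compound 1, at 5000 nM, with a range from 2000 nM to 12000 nM.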

Compound 3, half-maximal inhibitory concentration: 22000 nM
Compound 3: middle estimate off by 4.4-fold (0.64 log units), on the low side, outside the stated range (above it).
By their numbers in this assay, from the lowest: compounds 1 and 2 (each within the scatter of the next); then compound 3.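

In this assay, the group on this carbonyl carbon matters: piperazin-1-yl in place of (3-aminopropyl)amino gives a 5.2-fold higher number from compound 1 to compound 3 (0.72 log units; beyond the scatter), a modest step beyond the scatter. Within the data shown here, this is the first comparison here of compounds differing in one place, and the open-chain group gives the stronger inhibition of the two. No measurement offered here bears on the reason for this step.

On these data alone, it remains open whether a longer aminoalkyl chain, a morpholin-4-yl ring or a carboxylic acid on this carbonyl carbon would match compound 1. A single step also cannot show whether the change has the same size with other groups elsewhere on the core.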